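Fluoro in place of methyl on the shared core

The source may report more compounds than this note shows. Statements on the series, on what has been measured and on what is new or still open speak of the compounds shown alone.

Measured in a functional assay on SK-OV-3 cells (Homo sapiens) for cytotoxicity, read by MTT assay, with a stated time of 24 h; a lower number here means a stronger inhibitor, a higher number a weaker inhibitor:
Compound 1 `C#CCn1c(=O)c(/C=C/C(=O)/C=C(O)/C=C/c2ccc(O)c(OC)c2)cc2cc(OC)ccc21`: 14000 nM
Compound 2 `C#CCn1c(=O)c(/C=C/C(=O)/C=C(O)/C=C/c2ccc(O)c(OC)c2)cc2cc(C)ccc21`: 12800 nM

Among the measured compounds shown here, compound 2, at 12800 nM, lies within the scatter of compound 1, the only other measured compound. Compound 3 `C#CCn1c(=O)c(/C=C/C(=O)/C=C(O)/C=C/c2ccc(O)c(OC)c2)cc2cc(F)ccc21` has not yet been measured. It departs from compound 2 by fluoro in place of methyl on an aromatic carbon. For the measured compounds named here, the one measured step bearing on this, a 1.1-fold lower number from compound 1 to compound 2 (0.04 log units; within the scatter), put methyl in place of methoxy on an aromatic carbon. Going by the values given here, with only that step as a guide, no change beyond the scatter is expected in this assay, an estimated 1.0-fold higher number from compound 2 to compound 3 (0.01 log units; within the scatter). Compound 3 is expected at 13000 nM, with an estimated range of 7000 nM to 24000 nM.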

Compound 3, half-maximal inhibitory concentration: > 100000 nM
Compound 3: only a limit was reported; the forecaster's own chance of this, stated with the estimate: 3%; middle value at least 7.6-fold (0.88 log units) away from the limit.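

In this assay, methoxy and methyl at this position on the shared core lay within the scatter of each other, yet fluoro gives an at least 7.8-fold higher number from compound 2 to compound 3 (0.89 log units; beyond the scatter) and an at least 7.1-fold higher number from compound 1 to compound 3 (0.85 log units; beyond the scatter), so the group here can matter after all. Compound 3 gives > 100000 nM, which is a limit of the assay and not a number, so both steps are lower bounds.

The compounds shown leave open how chloro, an amine or a longer chain would behave here, and so whether fluoro alone stands apart from methyl and methoxy.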